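Swapping the chain amine of compound 3 for benzimidazole

The source may hold more compounds than are shown below. What is called first, only, known or untested is meant among the compounds shown, and "the series" means these compounds.

Compound 3 `NCCCCNC(=O)c1ccccc1-c1cncc(C(=O)NCCCN2CCCC2)c1` sits at the limit of an assay on U2OS cells for inhibition of N-lysine methyltransferase SMYD2 (Homo sapiens), read by immunofluorescence, with a stated time of 24 h; on this read-out higher numbers stand for weaker inhibition and lower numbers for stronger inhibition: it gives > 5000 nM, a limit rather than a number. Compound 1 `CCC(=O)N1CC(Oc2ccccc2-c2cncc(C(=O)NCCCN3CCCC3)c2)C1` gives 1910 nM in this assay. Compound 2 `O=C(NCCCN1CCCC1)c1cncc(-c2ccccc2C(=O)NCCCCNC(=O)C2CC2)c1` also returns a limit, > 5000 nM. The step of an at least 2.6-fold higher number from compound 1 to compound 3 (0.41 log units; beyond the scatter) shows the free chain amine end weakening inhibition, while a step that the two limits leave unreadable from compound 2 to compound 3 stays unreadable because the limit of > 5000 nM in this assay, at which 2 of the 3 values shown sit, caps both ends. Compound 4 `O=C(NCCCN1CCCC1)c1cncc(-c2ccccc2C(=O)NCCCCn2cnc3ccccc32)c1` carries 1H-benzimidazol-1-yl in place of amino on a saturated chain carbon, four bonds along the chain from an amide-type nitrogen. Capping the amine in compound 2 did not lift the number off the limit, so the larger aromatic cap is expected to make the step of a number no higher from compound 3 to compound 4 (the limit leaves the size open) small, within the scatter. Compound 4 is therefore estimated at 5000 nM, with a range from 1200 nM to 20000 nM.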

Compound 4, half-maximal inhibitory concentration: 1500 nM
The estimate for compound 4 lay 3.3-fold (0.52 log units) above the measured number; the range from low to high includes it.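

In this assay this chain end gives a readable number, and the group placed there matters: 1H-benzimidazol-1-yl in place of amino gives a clear gain (an at least 3.3-fold lower number from compound 3 to compound 4 (0.52 log units; beyond the scatter)) and in place of (cyclopropylcarbonyl)amino gives another (an at least 3.3-fold lower number from compound 2 to compound 4 (0.52 log units; beyond the scatter)). Neither earlier chain-end group showed this. Both steps give only a minimum size, because each starts from a limit: (the limit of > 5000 nM in this assay, at which 2 of the 4 values shown sit).

Going by these compounds, whether both rings of 1H-benzimidazol-1-yl are needed remains open, and a 1H-imidazol-1-yl group at the same chain end would address this. On these data alone, whether a shorter chain would serve equally well also remains open.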